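Removing One Trifluoromethyl From a Diaryl Urea

This account rests on a few compounds, and the source may have more. Where it says the series, first, only, none or still open, it means among the compounds named here.

Compound 1 `O=C(Nc1cccc(-n2cc(-c3ccncc3)c(-c3cc(O)cc(Cl)c3)n2)c1)Nc1ccc(Cl)c(C(F)(F)F)c1`: 94%
Compound 2 `COc1cc(Cl)cc(-c2nn(-c3cccc(NC(=O)Nc4cc(C(F)(F)F)cc(C(F)(F)F)c4)c3)cc2-c2ccncc2)c1`: 89%

Of the compounds shown here, two have been measured in a functional assay on MDA-MB-468 cells (Homo sapiens) for inhibition, read by sulforhodamine B assay, with a stated time of 48 h, tested at 0.1 uM; on this read-out lower numbers stand for a stronger effect and higher numbers for a weaker effect at the one concentration tested. Compound 1 gives 94% in this assay, and compound 2 gives 89%. Both numbers are high on this read-out, so neither compound produces much of an effect at the single concentration used. Compound 2 stands at the lower of the two numbers, but the gap to compound 1 falls within the usual scatter of repeated measurements, and the two cannot be told apart on these data alone.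

Compound 3 `COc1cc(Cl)cc(-c2nn(-c3cccc(NC(=O)Nc4cccc(C(F)(F)F)c4)c3)cc2-c2ccncc2)c1` has not yet been measured in this assay. It differs from compound 2 in one place: hydrogen in place of trifluoromethyl on an aromatic carbon. Among the measured compounds shown here, no step between measured compounds is available to guide the size of this change, so the expectation rests only on the two numbers above. Both measured compounds sit near the top of the read-out, and compound 3 is expected to remain in that region. The step of a number 3 percentage points higher from compound 2 to compound 3 (within the scatter) is estimated to be small, if anything toward a higher number, and not clearly beyond the scatter. Compound 3 is thus expected to give about 92%, with a range from 82% to 100%.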

Compound 3, a percentage reported as activity, at one concentration (the size of the read-out at that concentration, not a potency): 92%
Compound 3: the middle estimate sits on the measured number at the digits printed, and the stated range covers the measured number.
By their numbers in this assay, from the lowest: compounds 2, 3 and 1 (each within the scatter of the next).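

With the change of trifluoromethyl to hydrogen, this assay shows a number 3 percentage points higher from compound 2 to compound 3 (within the scatter) at this place, on an aromatic carbon of a six-membered aromatic ring of carbon only, meta to a large group and meta to a trifluoromethyl group. Among the compounds shown here, this is the first step here that can be read at a single place, as the two earlier compounds offered no such step, and it shows that, at the one concentration tested, this loss of four heavy atoms leaves no difference beyond the scatter. No accompanying measurement bears on why the numbers stay so close.

All of these numbers lie high on the read-out, so the step cannot separate a position that tolerates this change from a read-out showing too little effect at this concentration for any difference to appear. Also open, from the compounds shown here alone, is how an amine, a nitrile or a carboxylic acid on this same aromatic carbon would read, and whether the second trifluoromethyl group can be replaced by hydrogen with a similar result.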